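The source may report more compounds than this note shows. Statements on the series, on what has been measured and on what is new or still open speak of the compounds shown alone.

Of the compounds shown here, three sharing one core have been measured in a functional assay on the whole organism (6C3HED cells, Mus musculus) for inhibition, at a dose of 300 mg/kg by the oral route; on this read-out higher numbers stand for more inhibition at the one dose given (going by the name of the read-out) and lower numbers for less inhibition. Compound 1 `O=C(Nc1ccc(Cl)cc1)NS(=O)(=O)c1ccc(Cl)s1` gives 89%. Compound 2 `COc1ccc(S(=O)(=O)NC(=O)Nc2ccc(Cl)cc2)s1` gives 100%, and the step of a number 11 percentage points higher from compound 1 to compound 2 (beyond the scatter) goes with methoxy in place of chloro on an aromatic carbon. Compound 3 `CC(C)c1ccc(S(=O)(=O)NC(=O)Nc2ccc(Cl)cc2)s1` gives 63%, the lowest of the three numbers. The steps of a number 26 percentage points lower from compound 1 to compound 3 (beyond the scatter) and a number 37 percentage points lower from compound 2 to compound 3 (beyond the scatter) both fall as isopropyl enters in place of chloro or methoxy on an aromatic carbon, and both lie beyond the scatter.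

Compound 4 `CC(C)(C)c1ccc(S(=O)(=O)NC(=O)Nc2ccc(Cl)cc2)s1` has not yet been measured. It differs from compound 3 by methyl in place of hydrogen on a saturated chain carbon bound to an aromatic carbon and two saturated chain carbons, so the isopropyl becomes a tert-butyl. Among the compounds with values here, no measured pair covers this exact change; the two steps leading into compound 3 only show that an isopropyl at this place went with lower inhibition than a chloro or a methoxy. Adding one more carbon to that group is expected to lower the number somewhat further, or at most leave it within the scatter, so the step of a number 13 percentage points lower from compound 3 to compound 4 (beyond the scatter) is expected. Compound 4 is therefore estimated to give 50% in this assay, with a likely range from 25% to 75%.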

Compound 4, a percentage reported as inhibition, in the whole organism at one dose (the size of the read-out at that dose, not a potency): 10%
Beside the measured number, compound 4's estimate is 40 percentage points above it, and the stated range ends above it.
By their numbers in this assay, from the lowest: compound 4; then compound 3; then compound 1; then compound 2.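

At this place on the shared core, the change from isopropyl to tert-butyl adds only one methyl in place of one hydrogen, yet in this assay it goes with a number 53 percentage points lower from compound 3 to compound 4 (beyond the scatter) and so counts as a large step. The earlier compounds shown here showed that isopropyl went with less inhibition than chloro or methoxy, but they left compound 3 with a substantial read-out and gave no sign of how much one further methyl could matter. Set against the other two groups, tert-butyl goes with a number 79 percentage points lower from compound 1 to compound 4 (beyond the scatter) and with a number 90 percentage points lower from compound 2 to compound 4 (beyond the scatter) as well, so among these four compounds the choice of group at this place can separate nearly the full span of the read-out at this single dose.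

Going by these compounds, it remains open whether a straight chain such as n-butyl, a cyclopropyl group, an amine or a carboxylic acid at this place would stay close to methoxy or fall towards tert-butyl. On these data alone, because all four compounds keep the rest of the core unchanged, it also remains open whether the step from isopropyl to tert-butyl would be as large on a core carrying a different group elsewhere.

Nothing available here accounts for the size of this step.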